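Capping a hydroxy on a cyano-amide hydrazone

The compounds below may be only part of what the source reports. "The series", "measured", "known", "first", "only" and "open" are said of these compounds alone.

Values in a functional assay on MCF7 cells (Homo sapiens) for cytotoxicity, read by MTT assay, with a stated time of 24 h (a lower number here means a stronger inhibitor, a higher number a weaker inhibitor), so far are as follows

Compound 1 `C/C(=N\NC(=O)/C(C#N)=C/c1ccccc1)c1c(O)c2ccc(O)cc2oc1=O` gives 19200 nM
Compound 2 `C/C(=N\NC(=O)/C(C#N)=C/c1ccc(O)cc1)c1c(O)c2ccc(O)cc2oc1=O` gives 7320 nM
Compound 3 `COc1cc(/C=C(\C#N)C(=O)N/N=C(\C)c2c(O)c3ccc(O)cc3oc2=O)ccc1O` gives 13700 nM

Compound 3 stands within the usual scatter of both other compounds, with a 1.4-fold lower number from compound 1 to compound 3 (0.15 log units; within the scatter) and a 1.9-fold higher number from compound 2 to compound 3 (0.27 log units; within the scatter) as its two gaps. The next compound, compound 4 `COc1ccc(/C=C(\C#N)C(=O)N/N=C(\C)c2c(O)c3ccc(O)cc3oc2=O)cc1OC`, carries a single change methyl in place of hydrogen on an oxygen on an aromatic ring that is methyl in place of hydrogen on an oxygen on an aromatic ring, so hydroxy goes to methoxy and 4-hydroxy-3-methoxyphenyl goes to 3,4-dimethoxyphenyl.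

For the measured compounds named here, no measured step makes this exact change. The nearest evidence is the hydroxy added to compound 1, which gave a 2.6-fold lower number from compound 1 to compound 2 (0.42 log units; beyond the scatter) as a modest step, the only one here beyond the scatter. Losing the free hydroxy could therefore undo a little of that step, so a slightly higher number is expected, though probably nothing beyond the scatter. The expected step is a 1.2-fold higher number from compound 3 to compound 4 (0.07 log units; within the scatter) as an estimate. In this assay compound 4 is estimated at 16000 nM with an expected range of 8000 nM to 32000 nM here.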

Compound 4, half-maximal inhibitory concentration: 14400 nM
For compound 4 the middle estimate is 1.1-fold (0.05 log units) above the measured one; the range from low to high includes it.
By their numbers in this assay, from the lowest: compounds 2, 3, 4 and 1 (each within the scatter of the next, the first and the last beyond it).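

Putting a methyl on this oxygen, turning hydroxy into methoxy, makes no difference that can be read in this assay, with a 1.1-fold higher number from compound 3 to compound 4 (0.02 log units; within the scatter). With no free hydroxy left on the aromatic ring, compound 4 still cannot be told apart from either compound 2 or compound 1, with a 2.0-fold higher number from compound 2 to compound 4 (0.29 log units; within the scatter) and a 1.3-fold lower number from compound 1 to compound 4 (0.12 log units; within the scatter), even though those two compounds lie beyond the scatter of each other, so it does not show whether the free hydroxy matters here. Nothing available explains this result.

The compounds shown leave open whether a longer chain on this oxygen, such as ethyl or butyl, would give a number that stands clear of compound 3. They also leave open what an amine or a carboxylic acid would do on the same aromatic ring.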